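The same hydroxyl shift, tried on a second core

This account rests on a few compounds, and the source may have more. Where it says the series, first, only, none or still open, it means among the compounds named here.

Of the compounds shown here, three have been measured in a functional assay on HCT-15 cells (Homo sapiens) for cytotoxicity, read by CCK-8 assay; on this read-out lower numbers stand for stronger inhibition and higher numbers for weaker inhibition. Compound 1 `Oc1ccc(-c2cc(-c3ccco3)cc(-c3ccccc3O)n2)cc1` carries a 2-hydroxyphenyl group on an aromatic carbon of a six-membered aromatic ring with 1 nitrogen, next to the ring nitrogen, and in this assay compound 1 reaches only the limit of > 50000 nM. Compound 2 `Oc1ccc(-c2cc(-c3ccco3)cc(-c3cccc(O)c3)n2)cc1` differs from it by 3-hydroxyphenyl in place of 2-hydroxyphenyl on an aromatic carbon. In this assay compound 2 gives 840 nM. Among the compounds with values here, that step, an at least 59-fold lower number from compound 1 to compound 2 (1.77 log units; beyond the scatter), is the only measured step here, and because it starts from the limit of > 50000 nM in this assay, at which 2 of the 3 values shown sit, only its lower bound is known.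

Compound 3 `Oc1cccc(-c2cc(-c3ccoc3)cc(-c3ccccc3O)n2)c1` also reaches only the limit of > 50000 nM in this assay. The core of compound 3 and the core of compound 1 differ in more than one place, and the difference between the two cores is not broken down here. Compound 4 `Oc1cccc(-c2cc(-c3ccoc3)cc(-c3cccc(O)c3)n2)c1` is not yet measured. It differs from compound 3 by 3-hydroxyphenyl in place of 2-hydroxyphenyl on an aromatic carbon, the same kind of change as between compound 1 and compound 2, though the surroundings differ: in compound 3 the place is meta to a 3-hydroxyphenyl group and meta to a furan-3-yl group, whereas in compound 1 it is meta to a 4-hydroxyphenyl group and meta to a furan-2-yl group.

Within the data shown here, because the single measured example is an at least 59-fold lower number from compound 1 to compound 2 (1.77 log units; beyond the scatter) and the present step again begins from a limit, a step of the same direction is expected, an at least 25-fold lower number from compound 3 to compound 4 (1.39 log units; beyond the scatter), with its size quite uncertain. Compound 4 is therefore estimated at 2000 nM, within a range from 300 nM to 30000 nM.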

Compound 4, half-maximal inhibitory concentration: 1020 nM
For compound 4 the middle estimate is 2.0-fold (0.29 log units) above the measured one, within the range that was stated.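

In this assay, putting 3-hydroxyphenyl in place of 2-hydroxyphenyl on the second core gives an at least 49-fold lower number from compound 3 to compound 4 (1.69 log units; beyond the scatter), so the change works in the same direction on both cores and the step is large each time. Set side by side, the two steps read as follows: the same change on two cores in this assay, an at least 59-fold lower number (1.77 log units; beyond the scatter) from compound 1 to compound 2 and an at least 49-fold lower number (1.69 log units; beyond the scatter) from compound 3 to compound 4; the limit leaves it open whether they differ. Within the data shown here, this shows that the benefit of the swap is not confined to one core, but two cores are only two examples and the exact size of neither step is known, since each starts from a limit rather than a true value: the limit of > 50000 nM in this assay, at which 2 of the 4 values shown sit.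

The group at this place is a hydroxyphenyl in every compound shown, so it remains open whether the hydroxyl itself matters or whether a methoxy group, an amine or a carboxylic acid on the same phenyl ring would serve as well. The two cores also differ from each other in more than one place, which leaves open how the furan-2-yl and furan-3-yl groups and the position of the other hydroxyl each contribute to the values seen.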